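The compounds below may be only part of what the source reports. "The series", "measured", "known", "first", "only" and "open" are said of these compounds alone.

Compound 2 `COc1cccc(-c2nc(SC)nc3sc(C(=O)NCCO)c(N)c23)c1` carries a (2-hydroxyethyl)amino group on the amide carbonyl of the shared core. In a functional assay on HEK293 cells for agonist activity at Thyrotropin receptor (Homo sapiens), read by cAMP accumulation (on this read-out higher numbers stand for larger maximal responses and lower numbers for smaller maximal responses), compound 2 gives 2.9%. Compound 3 `COc1cccc(-c2nc(SC)nc3sc(C(=O)NC(C)(C)C)c(N)c23)c1OC` gives 3%, and compound 1 `COc1cccc(-c2nc(SC)nc3sc(C(=O)NNC(C)(C)C)c(N)c23)c1` gives 6.4%; the gap from compound 2 to each of them is within the scatter, so the three numbers sit together. Among the compounds with values here, the one measured step, a number 3.5 percentage points lower from compound 1 to compound 2 (within the scatter), also changed only the amine on that carbonyl and did not move the read-out beyond the scatter. Compound 4 `COc1cccc(-c2nc(SC)nc3sc(C(=O)N(C)C)c(N)c23)c1` differs from compound 2 at the same place: dimethylamino in place of (2-hydroxyethyl)amino on a carbonyl carbon. Because a number 3.5 percentage points lower from compound 1 to compound 2 (within the scatter) was within the scatter, no step beyond the scatter is expected here either. Compound 4 is therefore expected to give about 4%, within 0% to 14%, a step of a number 1.1 percentage points higher from compound 2 to compound 4 (within the scatter).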

Compound 4, largest response reached (reported as efficacy), in percent of the reference or control that the assay uses: 4%
Compound 4: middle estimate and measured number agree at the digits printed; the range from low to high includes it.
By their numbers in this assay, from the lowest: compounds 2, 3, 4 and 1 (each within the scatter of the next).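

In this assay the change to dimethylamino gives a number 1.1 percentage points higher from compound 2 to compound 4 (within the scatter) and so removes the 2 hydrogen-bond donors of (2-hydroxyethyl)amino without the read-out leaving the scatter. Set against ((tert-butyl)amino)amino, dimethylamino gives a number 2.4 percentage points lower from compound 1 to compound 4 (within the scatter) and thus three different groups on this carbonyl carbon now read alike. No measurement available here offers a reason for this. Still open, on these data alone, is whether a carboxylic acid, a piperazine or a longer chain on this carbonyl carbon would move the response beyond the scatter.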